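Methyl on a Phenol Oxygen in Two Related Compounds

This account rests on a few compounds, and the source may have more. Where it says the series, first, only, none or still open, it means among the compounds named here.

Compound 1 `O=C(Nc1cccc(-n2cc(-c3ccncc3)c(-c3cc(O)cc(Cl)c3)n2)c1)Nc1ccc(Cl)c(C(F)(F)F)c1` and compound 2 `COc1cc(Cl)cc(-c2nn(-c3cccc(NC(=O)Nc4ccc(Cl)c(C(F)(F)F)c4)c3)cc2-c2ccncc2)c1` share one core and differ in a single place: methyl in place of hydrogen on an oxygen on an aromatic ring. In a functional assay on K562 cells (Homo sapiens) for inhibition, read by sulforhodamine B assay, with a stated time of 48 h, tested at 10 uM (on this read-out higher numbers stand for a weaker effect at the one concentration tested and lower numbers for a stronger effect), compound 1 gives 5.24%, and compound 2 gives 8.93%, so that a number 3.7 percentage points higher from compound 1 to compound 2 (within the scatter). Compound 3 `O=C(Nc1cccc(-n2cc(-c3ccncc3)c(-c3cc(O)cc(Cl)c3)n2)c1)c1cc(C(F)(F)F)cc(C(F)(F)F)c1` rests on a different core; the difference between the two cores is not broken down here. In this assay compound 3 gives 20.4%, the highest of the three numbers and beyond the scatter from both compound 1 and compound 2. Compound 4 `COc1cc(Cl)cc(-c2nn(-c3cccc(NC(=O)c4cc(C(F)(F)F)cc(C(F)(F)F)c4)c3)cc2-c2ccncc2)c1` arises from compound 3 by the same change, (methyl in place of hydrogen on an oxygen on an aromatic ring), at a place described in identical words. Because the measured step of a number 3.7 percentage points higher from compound 1 to compound 2 (within the scatter) stayed within the scatter, a similarly small step is expected here, a number 3.6 percentage points higher from compound 3 to compound 4 (within the scatter). Compound 4 is therefore estimated to give 24%, between 12% and 38%.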

Compound 4, a percentage reported as activity, at one concentration (the size of the read-out at that concentration, not a potency): 38%
Compound 4: middle estimate off by 14 percentage points, on the low side, and the stated range covers the measured number.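

With hydroxy changed to methoxy on the core of compound 3, this assay gives a number 17.6 percentage points higher from compound 3 to compound 4 (beyond the scatter), so the effect at the one concentration tested is weaker. Set beside the same change on the core of compound 1, the gap between the two steps does not exceed what scatter allows: the same change on two cores in this assay, a number 3.7 percentage points higher (within the scatter) from compound 1 to compound 2 and a number 17.6 percentage points higher (beyond the scatter) from compound 3 to compound 4, 13.9 percentage points apart, within the scatter of two such steps. Within the data shown here, this shows no measurable dependence on the core, but with only two pairs, one step within the scatter and the other beyond it, it does not establish that the step carries over unchanged.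

The compounds shown leave open how a longer chain such as ethyl on that oxygen, or an amine in place of the hydroxy, would read. As far as these compounds go, whether the step holds on any further core also remains open.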